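Cytotoxicity across the aryl amide series: compound 4

The source may report more compounds than this note shows. Statements on the series, on what has been measured and on what is new or still open speak of the compounds shown alone.

The three measured compounds share one core; compound 1 `C/C(=N\NC(=O)c1ccncc1)C(=O)Nc1ccc(C(F)(F)F)cc1` carries a trifluoromethyl group, compound 2 `C/C(=N\NC(=O)c1ccncc1)C(=O)Nc1ccc(OC(F)(F)F)cc1` a trifluoromethoxy group, and compound 3 `C/C(=N\NC(=O)c1ccncc1)C(=O)Nc1cccc(Cl)c1` a 3-chlorophenyl on the amide-type nitrogen. In an ADME assay on HepG2 cells (Homo sapiens) for cytotoxicity, read by MTT assay (a higher number here means a weaker inhibitor, a lower number a stronger inhibitor), compound 1 reports only a limit, > 50000 nM. Compound 2 likewise gives a limit in this assay, > 50000 nM. Compound 3 also sits at a limit, > 50000 nM. The step that the two limits leave unreadable from compound 1 to compound 2 is therefore not sizeable from the two limits. Where compound 3 stands is thus the limit itself, shared by every value in the series, as summarised by the limit of > 50000 nM in this assay, at which 3 of the 3 values shown sit.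

Compound 4 `C/C(=N\NC(=O)c1ccncc1)C(=O)Nc1ccc(Br)cc1` differs from compound 3 by 4-bromophenyl in place of 3-chlorophenyl on an amide-type nitrogen. Among the measured compounds shown here, no measured step with a readable size bears on this change; the single step between measured compounds is unreadable, and all three values sit at the limit (the limit of > 50000 nM in this assay, at which 3 of the 3 values shown sit). Nothing in these numbers points to a step in this assay in either direction beyond the scatter, so the expectation for compound 4 is the same limit, with a number no higher from compound 3 to compound 4 (the limit leaves the size open) expected to be close to none. Compound 4 is estimated at 50000 nM, with a range from 20000 nM to 200000 nM, and is most likely to be reported again as a limit.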

Compound 4, half-maximal inhibitory concentration: > 50000 nM
Compound 4: only a limit was reported; the forecaster's own chance of this, stated with the estimate: 85%; the middle value lies on the limit itself.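

Compound 4 joins compound 1, compound 2 and compound 3 at a limit, so none of the steps from those three compounds to compound 4 can be read: the limit of > 50000 nM in this assay, at which 4 of the 4 values shown sit.

The compounds shown leave open how far each of the four lies beyond that limit in this assay, and whether any of these aryl changes shifts the read-out at all.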